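Sulfonamide nitrogen methylation and hepatocyte clearance in the series

The source may hold more compounds than are shown below. What is called first, only, known or untested is meant among the compounds shown, and "the series" means these compounds.

Measured so far:
Compound 1 `Cc1cc(COc2ccc(S(=O)(=O)NC3(C(=O)NO)CN(C(=O)C(C)C)C3)cc2)c2ccccc2n1` gives < 5 uL/min in an ADME assay on cells (Hepatocyte, Homo sapiens) for metabolic stability, read by LC-MS, tested at 1 uM (a higher number here means faster removal of the compound, a lower number slower removal), which is a limit of the assay and not a number.
Compound 2 `Cc1cc(COc2ccc(S(=O)(=O)N(C)C3(C(=O)NO)CN(C(=O)C(C)C)C3)cc2)c2ccccc2n1` gives 8 uL/min in this assay.
Compound 3 `Cc1cc(COc2ccc(S(=O)(=O)NC3(C(=O)NO)CN(C(=O)CC(C)C)C3)cc2)c2ccccc2n1` gives 6 uL/min in this assay.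

Among the compounds with values here, compound 3 and compound 2 are the only plain numbers here, and they sit within the scatter of each other in this assay. Compound 4 `Cc1cc(COc2ccc(S(=O)(=O)N(C)C3(C(=O)NO)CN(C(=O)CC(C)C)C3)cc2)c2ccccc2n1` differs from compound 3 by methyl in place of hydrogen on a sulfonamide nitrogen. The same change has been made once before in the series, giving an at least 1.6-fold higher number from compound 1 to compound 2 (0.20 log units; that floor lies within the scatter). That step starts from a limit (the limit of < 5 uL/min in this assay, at which 1 of the 3 values shown sits), so its true size is not pinned down, and its floor lies within the scatter. The other measured step, an at least 1.2-fold higher number from compound 1 to compound 3 (0.07 log units; that floor lies within the scatter), also starts from that limit and is likewise within the scatter at its floor. On this basis the step to compound 4 in this assay is expected to be small, if anything a modest rise, and not clearly beyond the scatter: expected a 1.3-fold higher number from compound 3 to compound 4 (0.12 log units; within the scatter). Compound 4 is therefore estimated at 8 uL/min, with a range from 4 uL/min to 16 uL/min.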

Compound 4, intrinsic clearance in a liver preparation (reported as CLH), per the amount of preparation that the assay uses in the Hepatocyte assay: 14 uL/min
Compound 4: the middle estimate sits 1.8-fold (0.24 log units) below what was measured; the range from low to high includes it.
By their numbers in the Hepatocyte assay, from the lowest: compounds 3, 2 and 4 (each within the scatter of the next, the first and the last beyond it). At a limit, below all of these: compound 1.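

In the Hepatocyte assay, methyl in place of hydrogen on a sulfonamide nitrogen now has a step that starts from a plain number and clears the scatter, a 2.3-fold higher number from compound 3 to compound 4 (0.37 log units; beyond the scatter). Isobutyl in place of isopropyl on a carbonyl carbon, read on the methylated pair, stays inside the scatter, a 1.8-fold higher number from compound 2 to compound 4 (0.24 log units; within the scatter). The same methyl pair also parts in a physicochemical assay for solubility, with a stated time of 24 h, tested at 30 mg/mL (a lower number here means a less soluble compound, a higher number a more soluble compound), where compound 3 gives 5000000 nM and compound 4 gives 45000000 nM.

On these data alone, the steps from compound 1 start from a limit of the assay and cannot be read for size, so whether the methyl step has the same size on both cores stays open: the same change on two cores in the Hepatocyte assay, an at least 1.6-fold higher number (0.20 log units; that floor lies within the scatter) from compound 1 to compound 2 and a 2.3-fold higher number (0.37 log units; beyond the scatter) from compound 3 to compound 4; the limit leaves it open whether they differ How a longer chain such as ethyl on a sulfonamide nitrogen would read in the Hepatocyte assay or the physicochemical assay also stays open.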